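A Methyl Group Moved One Carbon Further Out

The source may hold more compounds than are shown below. What is called first, only, known or untested is meant among the compounds shown, and "the series" means these compounds.

Compound 1, `CCNC1=NS(=O)(=O)c2cc(F)ccc2N1`, and compound 2, `CC(C)NC1=NS(=O)(=O)c2cc(F)ccc2N1`, differ in one place: methyl in place of hydrogen on a saturated chain carbon bound to an amine nitrogen and a saturated chain carbon. In a functional assay (aorta) with Rattus norvegicus as the target (a higher number here means that more compound is needed for the effect, a lower number that less compound is needed), compound 1 gives > 300 uM, which is a limit of the assay and not a number. In this assay compound 2 gives 43.1 uM. The step of an at least 6.9-fold lower number from compound 1 to compound 2 (0.84 log units; beyond the scatter) is known only as a lower bound because one of its two ends sits at the limit of > 300 uM in this assay, at which 1 of the 3 values shown sits.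

Compound 3, `CCC(C)NC1=NS(=O)(=O)c2cc(Cl)ccc2N1`, carries a different core; the difference between the two cores is not broken down here. In this assay compound 3 gives 15.5 uM, the lowest of the two numbers, with compound 2 as its nearest neighbour at a gap beyond the scatter.

Compound 4, `CC(C)C(C)NC1=NS(=O)(=O)c2cc(Cl)ccc2N1`, has not yet been measured. It differs from compound 3 in one place: methyl in place of hydrogen on a saturated chain carbon bound to two saturated chain carbons. For the measured compounds named here, this is the same kind of change as the one from compound 1 to compound 2, but not the same: there the entering methyl sat on a saturated chain carbon bound to an amine nitrogen and a saturated chain carbon, here it sits on a saturated chain carbon bound to two saturated chain carbons.

Going by the values given here, for compound 4 the step of a 1.9-fold lower number from compound 3 to compound 4 (0.29 log units; within the scatter) in this assay is expected to be smaller than the earlier one, since the only guide is compound 2 with 43.1 uM and the change now lands one carbon further from the amine nitrogen. Compound 4 is estimated to give 8 uM in this assay, within 3 uM to 25 uM.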

Compound 4, concentration for half-maximal effect: 1.2 uM
Estimate against measurement, compound 4: 6.7-fold (0.82 log units) above; the measured number lies below the stated range.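

In this assay, a methyl in place of hydrogen on a saturated chain carbon bound to two saturated chain carbons produces a 13-fold lower number from compound 3 to compound 4 (1.11 log units; beyond the scatter). Set beside the earlier step, this shows that adding a methyl to the amine side chain moved the number in the same direction on both cores, at least in these two pairs: the same change on two cores in this assay, an at least 6.9-fold lower number (0.84 log units; beyond the scatter) from compound 1 to compound 2 and a 13-fold lower number (1.11 log units; beyond the scatter) from compound 3 to compound 4; the limit leaves it open whether they differ. Going by these compounds, compound 1 gives > 300 uM, which is a limit of the assay and not a number, so the size of the earlier step stays open; the methyl also enters on a different kind of chain carbon in each pair, so the two pairs show a shared direction but no rule that would predict the size of the step on another core.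

The compounds shown include no pair with the same side chain on both cores, so the effect of the core alone cannot be read from them. On these data alone, it also remains open whether the number would keep falling with a longer chain such as a hexyl group, or whether a cyclohexyl ring or a terminal amine on the side chain would be tolerated in its place.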